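Removing the methoxy from the aryl group on the alkyne

This account rests on a few compounds, and the source may have more. Where it says the series, first, only, none or still open, it means among the compounds named here.

Compound 1 `COC(=O)c1sc2cc(C#Cc3ccc(OC)cc3)cnc2c1N` has the lowest of the two numbers available in a functional assay on MCF7 cells (Homo sapiens) for inhibition, read by sulforhodamine B assay, with a stated time of 48 h; a higher number here means a weaker inhibitor of growth, a lower number a stronger inhibitor of growth: compound 1 gives 460 nM. Its nearest neighbour is compound 3 `COC(=O)c1sc2cc(C#Cc3ccccc3N)cnc2c1N`, which in this assay gives 4100 nM. Compound 2 `COC(=O)c1sc2cc(C#Cc3cccnc3)cnc2c1N` reaches only a limit of this assay, > 150000 nM. Compound 4 `COC(=O)c1sc2cc(C#Cc3ccccc3)cnc2c1N` differs from compound 1 by hydrogen in place of methoxy on an aromatic carbon. Among the measured compounds shown here, no measured step removes this group alone; the two steps that exchange the aryl group on the triple-bonded carbon, an 8.9-fold higher number from compound 1 to compound 3 (0.95 log units; beyond the scatter) and an at least 320-fold higher number from compound 1 to compound 2 (2.51 log units; beyond the scatter), both raise the number, one modestly and one up to the limit of > 150000 nM in this assay, at which 1 of the 3 values shown sits. A modest rise in this assay is therefore expected for compound 4, a 2.6-fold higher number from compound 1 to compound 4 (0.42 log units; beyond the scatter). Compound 4 is estimated at 1200 nM, within 400 nM to 4000 nM.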

Compound 4, concentration for 50% growth inhibition: > 150000 nM
Compound 4 was reported as a limit; the forecaster's own chance of this, stated with the estimate: 5%; at least 120-fold (2.09 log units) between middle value and limit.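

Taking the methoxy away gives an at least 320-fold higher number from compound 1 to compound 4 (2.51 log units; beyond the scatter), and taking the amino away gives an at least 36-fold higher number from compound 3 to compound 4 (1.56 log units; beyond the scatter), so among these compounds the unsubstituted phenyl loses the measurable growth inhibition that either substituent retains. Compound 4 gives > 150000 nM, which is a limit of this assay and not a number. The step between compound 2 and compound 4 cannot be read: the limit of > 150000 nM in this assay, at which 2 of the 4 values shown sit.

Going by these compounds, whether a hydroxyl, a fluorine or an ethoxy on the same aromatic carbon would retain the activity of compound 1 stays open. So does the effect of an amine there, as in a 4-aminophenyl group.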